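A Pyrrolidine at the End of the Chain

A few compounds are considered here, and "the series" means these few. Any claim that something is new, unique, unknown or untested is made for them only; others in the source may bear on it.

- Compound 1 `CC(C)=CCCC(C)=CCNCCN` gives 36200 nM
- Compound 2 `CC(C)=CCCC(C)=CCNCCCN` gives > 150000 nM, a limit

Both compounds were tested in a toxicity assay on CHO cells (Cricetulus griseus) for cytotoxicity, read by WST assay, with a stated time of 24 h; a lower number here means a stronger inhibitor, a higher number a weaker inhibitor. Compound 2 has no exact number, because > 150000 nM is a limit of the assay. Compound 3 `CC(C)=CCCC(C)=CCNCCCN1CCCC1` differs from compound 2 at the end of the chain, with pyrrolidin-1-yl in place of amino on a saturated chain carbon, three bonds along the chain from an amine nitrogen. For the measured compounds named here, no measured step tests this exact change. The nearest guide is an at least 4.1-fold higher number from compound 1 to compound 2 (0.61 log units; beyond the scatter), a different change in which aminomethyl replaces amino. Going by an at least 4.1-fold higher number from compound 1 to compound 2 (0.61 log units; beyond the scatter), a step of similar size is expected here, toward a lower number, although a second limit remains possible. This estimated step is an at least 2.1-fold lower number from compound 2 to compound 3 (0.33 log units; beyond the scatter). For compound 3 the expected value in this assay is 70000 nM, with an estimated range from 30000 nM to 150000 nM.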

Compound 3, half-maximal inhibitory concentration: > 150000 nM
Compound 3: only a limit was reported (the forecaster's own chance of this, stated with the estimate: 35%); at least 2.1-fold (0.33 log units) between middle value and limit.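

Compound 3 gives only a limit in this assay, as compound 2 does, so the step between these two cannot be read. What can be read is an at least 4.1-fold higher number from compound 1 to compound 3 (0.61 log units; beyond the scatter), which places compound 3 on the same side of compound 1 as compound 2. Replacing the end amino group with pyrrolidin-1-yl therefore brings no number below the limit, and the order of compound 2 and compound 3 stays hidden because both sit at one limit: the limit of > 150000 nM in this assay, at which 2 of the 3 values shown sit.

From the compounds shown here alone, whether pyrrolidin-1-yl on the shorter chain of compound 1 would give a readable number remains open. The same holds for a piperidine ring or a dimethylamino group at that chain end.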